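Removing the bromo group: what a bare phenyl ring may give

A few compounds are considered here, and "the series" means these few. Any claim that something is new, unique, unknown or untested is made for them only; others in the source may bear on it.

Compounds measured so far:
- compound 1, `CC(=O)N1N=C(c2ccc(OCc3cn(Cc4ccc([N+](=O)[O-])cc4)nn3)cc2)CC1c1ccccc1`: 0%
- compound 2, `COc1cc(C2CC(c3ccc([N+](=O)[O-])cc3)=NN2C(C)=O)ccc1OCc1cn(Cc2ccc([N+](=O)[O-])cc2)nn1`: 7%
- compound 3, `COc1cc(C2CC(c3ccc(Br)cc3)=NN2C(C)=O)ccc1OCc1cn(Cc2ccc([N+](=O)[O-])cc2)nn1`: 1%

In a functional assay on THP-1 cells (Homo sapiens) for inhibition, read by sulforhodamine B assay, tested at 10 uM (on this read-out higher numbers stand for more inhibition of growth at the one concentration tested and lower numbers for less inhibition of growth), compound 1 gives 0%, compound 2 gives 7%, and compound 3 gives 1%. All three numbers sit close to the bottom of the scale, and every gap between them lies within the usual scatter of this kind of measurement, so none of the three can be called more or less active than another. Compound 3 stands second of the three on the raw numbers, but its nearest neighbour, compound 1, and its furthest, compound 2, are both within the scatter of it.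

Compound 4, `COc1cc(C2CC(c3ccccc3)=NN2C(C)=O)ccc1OCc1cn(Cc2ccc([N+](=O)[O-])cc2)nn1`, differs from compound 3 in one place: hydrogen in place of bromo on an aromatic carbon. For the measured compounds named here, the one measured step that bears on a change at this aromatic carbon is a number 6 percentage points lower from compound 2 to compound 3 (within the scatter), which stayed within the scatter. Compound 1, which also carries a plain phenyl ring at that end of the molecule, shows a number close to compound 3. On this basis the step of a number 1 percentage points higher from compound 3 to compound 4 (within the scatter) is expected to be none beyond the scatter.

Compound 4 is therefore estimated to give 2% in this assay, within a range from -8% to 12%.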

Compound 4, percent growth inhibition at one concentration: 0%
Compound 4: middle estimate off by 2 percentage points, on the high side, within the range that was stated.
By their numbers in this assay, from the lowest: compounds 1, 4, 3 and 2 (each within the scatter of the next).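

In this assay, the change from 4-bromophenyl to phenyl gives a number 1 percentage points lower from compound 3 to compound 4 (within the scatter), and hydrogen in place of nitro on the same aromatic carbon gives a number 7 percentage points lower from compound 2 to compound 4 (within the scatter). Together with the earlier swap of nitro for bromo, which gave a number 6 percentage points lower from compound 2 to compound 3 (within the scatter), this means that the position has now carried nitro, bromo and hydrogen, so the bare phenyl ring serves as a measured baseline, and neither group shows growth inhibition that can be told apart from that baseline. The compounds shown offer no independent measurement that could explain these numbers.

On these data alone, whether an amine, a carboxylic acid or a longer chain on this aromatic carbon would give a number beyond the scatter of compound 2, compound 3 and compound 4 remains open. As far as these compounds go, with only one concentration tested and all of these numbers close to the bottom of the scale, it also remains open whether swapping groups at this position would make any difference at higher concentrations, where a change too small to see here might become clear.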